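Swapping a naphthalene for a fluorophenyl in a weak inhibitor

The compounds below may be only part of what the source reports. "The series", "measured", "known", "first", "only" and "open" are said of these compounds alone.

Measured compounds:
- Compound 1, `CC(C)[C@H](NC(=O)COc1cccc2ccccc12)C(=O)N[C@@H](CC(=O)O)C(=O)COc1ccc2ccccc2c1`: 15900 nM
- Compound 2, `CC(C)[C@H](NC(=O)COc1cccc2ccccc12)C(=O)N[C@@H](CC(=O)O)C(=O)COc1ccc(Oc2ccc(C(F)(F)F)cc2)cc1`: 24900 nM

Both compounds were tested in a functional assay with Homo sapiens as the target; a higher number here means a weaker inhibitor, a lower number a stronger inhibitor. Compound 1 gives 15900 nM, and compound 2 gives 24900 nM. Compound 1 shows the lower of the two numbers, but the gap to compound 2 lies within the usual scatter of repeated measurements, so neither can be called the stronger inhibitor. Both are weak.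

Compound 3, `CC(C)[C@H](NC(=O)COc1cccc2ccccc12)C(=O)N[C@@H](CC(=O)O)C(=O)COc1cccc(F)c1`, has not yet been measured. It differs from compound 1 in one place: 3-fluorophenyl in place of naphthalen-2-yl on an oxygen on a saturated carbon. Going by the values given here, no measured pair of compounds shows a step of this kind, so the expectation rests only on the two measured values, which sit close together despite differing in the same region of the molecule.

The step from compound 1 to compound 3 is expected to be small, a 1.6-fold higher number from compound 1 to compound 3 (0.20 log units; within the scatter), with no clear direction beyond the scatter. Compound 3 is therefore estimated at 25000 nM in this assay, within a range from 8000 nM to 80000 nM.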

Compound 3, half-maximal inhibitory concentration: 12000 nM
Estimate against measurement, compound 3: 2.1-fold (0.32 log units) above; low and high end bracket the measured number.
By their numbers in this assay, from the lowest: compounds 3, 1 and 2 (each within the scatter of the next, the first and the last beyond it).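

In this assay, putting 3-fluorophenyl in place of naphthalen-2-yl on the oxygen gives a 1.3-fold lower number from compound 1 to compound 3 (0.12 log units; within the scatter), so the step cannot be told apart from repeat-measurement noise and the two compounds read alike. The change takes this group from 10 heavy atoms and 2 aromatic rings to 7 heavy atoms and one aromatic ring, which shows that, at this position, compound 3 keeps the same weak level of inhibition as compound 1 with a single ring in place of two. Nothing measured here explains why these two groups read alike.

The step swaps the ring system and adds a fluorine in one move, and it does not separate these two changes from each other; an unsubstituted phenyl in the same place would be the group to tell them apart. Going by these compounds, it also remains open whether an amine or a carboxylic acid on this ring, or a longer carbon chain in place of the ring, would move the number beyond the scatter, in either direction, from the weak level seen with the shared core.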